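The compounds below may be only part of what the source reports. "The series", "measured", "known", "first", "only" and "open" are said of these compounds alone.

The measured compounds:

compound 1, `O=C(Nc1cccc(-n2cc(-c3ccncc3)c(-c3cc(O)cc(Cl)c3)n2)c1)Nc1ccc(Cl)c(C(F)(F)F)c1`, gives 34.3% in a functional assay on HCC 2998 cells (Homo sapiens) for inhibition, read by sulforhodamine B assay, with a stated time of 48 h, tested at 10 uM; on this read-out lower numbers stand for a stronger effect and higher numbers for a weaker effect at the one concentration tested
compound 2, `COc1cc(Cl)cc(-c2nn(-c3cccc(NC(=O)Nc4ccc(Cl)c(C(F)(F)F)c4)c3)cc2-c2ccncc2)c1`, gives 18.1% in this assay
compound 3, `O=C(Nc1cccc(-n2cc(-c3ccncc3)c(-c3cc(O)cc(Cl)c3)n2)c1)c1cc(C(F)(F)F)cc(C(F)(F)F)c1`, gives 28.9% in this assay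

Compound 1 and compound 2 differ in one place: methyl in place of hydrogen on an oxygen on an aromatic ring. That change made the step of a number 16.2 percentage points lower from compound 1 to compound 2 (beyond the scatter). Compound 3 sits close to compound 1, with the two values within the usual scatter of each other, so nothing can be read from that pair; the difference between the two cores of compound 1 and compound 3 is not broken down here.

Compound 4, `COc1cc(Cl)cc(-c2nn(-c3cccc(NC(=O)c4cc(C(F)(F)F)cc(C(F)(F)F)c4)c3)cc2-c2ccncc2)c1`, is not yet measured. Going by the values given here, it differs from compound 3 by methyl in place of hydrogen on an oxygen on an aromatic ring, the same change as the one from compound 1 to compound 2, at a place described in the same words. Among the compounds with values here, only one earlier step of this kind is known, so the expectation rests on a single example. Because the earlier step was a number 16.2 percentage points lower from compound 1 to compound 2 (beyond the scatter), the step of a number 13.9 percentage points lower from compound 3 to compound 4 (beyond the scatter) is expected. Compound 4 is therefore estimated at 15% in this assay, most likely between 4% and 30%.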

Compound 4, a percentage reported as activity, at one concentration (the size of the read-out at that concentration, not a potency): 78.3%
Estimate against measurement, compound 4: 63.3 percentage points below; the whole stated range lies below it.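

Changing hydroxy to methoxy on the 3-chloro-5-hydroxyphenyl group gave a number 49.4 percentage points higher from compound 3 to compound 4 (beyond the scatter) in this assay, which means a weaker effect at the one concentration tested. Set beside the earlier step, the same change moved the read-out in opposite directions on the two cores: the same change on two cores in this assay, a number 16.2 percentage points lower (beyond the scatter) from compound 1 to compound 2 and a number 49.4 percentage points higher (beyond the scatter) from compound 3 to compound 4, 65.6 percentage points apart, beyond the scatter of two such steps. In these compounds, then, the result of this change on one core did not predict its result on the other, but two pairs cannot show why the direction reversed or how the change would behave on any further core.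

The compounds shown leave open whether a longer chain on this oxygen, such as ethyl in place of methyl, or an amine in place of the hydroxy, would follow the pattern of the core of compound 1 or that of compound 3. They also leave open which part of the difference between these two cores decides the direction of the step.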